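The source may report more compounds than this note shows. Statements on the series, on what has been measured and on what is new or still open speak of the compounds shown alone.

For the measured compounds named here, in a functional assay on the whole organism (strain Sprague-Dawley) for inhibition, with Rattus norvegicus as the target, with a stated time of 10 min (a lower number here means that less compound is needed, a higher number that more compound is needed for the effect), compound 1 (`Nc1ccccc1-c1ncc(C(=O)O)c(=O)[nH]1`) gives 50 mg/kg, the only number in this small set. Compound 2 (`CCOc1ccc(S(=O)(=O)Cl)cc1-c1ncc(C(=O)O)c(=O)[nH]1`) is recorded as "not determined" (no result reported). Compound 3 (`CCOC(=O)c1cnc(-c2ccccc2N)[nH]c1=O`) is recorded as "not determined" (no result reported), so compound 3 offers no number to start from. Compound 4 (`CCCOc1ccccc1-c1ncc(C(=O)OCC)c(=O)[nH]1`) has yet to be measured. The structural change is propoxy in place of amino on an aromatic carbon. Going by the values given here, no measured step shows what such a swap does in this assay, so the expectation is tentative: a moderate step to a lower dose than compound 1, at 50 mg/kg, is expected. Compound 4 is estimated at 8 mg/kg, with an expected range from 1 mg/kg to 50 mg/kg.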

Compound 4, dose for 50% inhibition: 5 mg/kg
Beside the measured number, compound 4's estimate is 1.6-fold (0.20 log units) above it, and the stated range covers the measured number.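

Compound 3 has no single number to set against compound 4, and compound 4 differs from compound 1 in more than one place, so no step can be read. Nothing shown explains the result. From the compounds shown here alone, what swapping amino for propoxy alone does to the dose remains open.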